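A few compounds are considered here, and "the series" means these few. Any claim that something is new, unique, unknown or untested is made for them only; others in the source may bear on it.

Compound 1, `O=C(CN(c1nc(Cl)nc2[nH]cnc12)C1CC1)N[C@@H](CCC(=O)OCc1ccccc1)C(=O)OCc1ccccc1`, is the reference point of this account. In a functional assay on the whole organism (Tail, strain ICR) with Mus musculus as the target, in the tail flick test, with a stated time of 150 min, at a dose of 25 umol/kg by the oral route (on this read-out lower numbers stand for a weaker effect and higher numbers for a stronger effect at the one dose given), compound 1 gives 44.5%, the highest of the three numbers measured. Compound 3, `CC(C)[C@H](NC(=O)CN(c1ncnc2c1ncn2C1CCCCO1)C1CC1)C(=O)OCc1ccccc1`, comes nearest to it: in this assay compound 3 gives 21.1%, a gap beyond the scatter. Compound 2, `CSCC[C@H](NC(=O)CN(c1ncnc2c1ncn2C1CCCCO1)C1CC1)C(=O)OCc1ccccc1`, stands furthest away: in this assay compound 2 gives 17.5%, again beyond the scatter from compound 1. Compounds 2 and 3 share a core that differs from that of compound 1, so they report on the side chain rather than on the core of compound 1.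

Compound 4, `NC(=O)C[C@H](NC(=O)CN(c1nc(Cl)nc2[nH]cnc12)C1CC1)C(=O)OCc1ccccc1`, has not yet been measured. It differs from compound 1 in one place: carbamoyl in place of (benzyloxycarbonyl)methyl on a saturated chain carbon, two bonds along the chain from an amide-type nitrogen and a carbonyl carbon.

Within the data shown here, the one measured step on a side chain, a number 3.6 percentage points higher from compound 2 to compound 3 (within the scatter), lies within the scatter, and it was made on the other core and exchanged two chain groups of similar size. On these data alone, nothing measured covers the loss of the benzyloxycarbonyl group from compound 1 itself, so its weight is unknown. On these grounds compound 4 is expected to fall somewhat below compound 1, with the step of a number 11.5 percentage points lower from compound 1 to compound 4 (beyond the scatter) as the estimate. For compound 4 the estimated value in this assay is 33%, within a range from 12% to 55%.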

Compound 4, a percentage reported as activity, at one dose (the size of the read-out at that dose, not a potency): 13.5%
Beside the measured number, compound 4's estimate is 19.5 percentage points above it, within the range that was stated.
By their numbers in this assay, from the lowest: compounds 4, 2 and 3 (each within the scatter of the next); then compound 1.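

In this assay the exchange of (benzyloxycarbonyl)methyl for carbamoyl on the core of compound 1 gives a large step, a number 31 percentage points lower from compound 1 to compound 4 (beyond the scatter), whereas the only earlier side-chain step, a number 3.6 percentage points higher from compound 2 to compound 3 (within the scatter), was made on another core and lay within the scatter, so this position is the first shown where the group carried clearly changes the read-out. The change is not a single one, since 11 heavy atoms and a six-membered aromatic ring of carbon only leave, while 3 heavy atoms and a hydrogen-bond donor enter, and this one step cannot separate these differences. Nothing available explains the size of the step.

On these data alone, it remains open how a carboxylic acid, an amine or a longer chain ending in carbamoyl would read at this position on the core of compound 1, and thus whether the aromatic ring, the chain length or the carbamoyl group itself accounts for the step. As far as these compounds go, it also remains open whether the same exchange would give a step of similar size on the core shared by compound 2 and compound 3.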